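This account rests on a few compounds, and the source may have more. Where it says the series, first, only, none or still open, it means among the compounds named here.

Compound 1 `COc1c(NS(=O)(=O)c2ccc(F)cc2)cc(-c2ccc3nc(NC4CC4)sc3n2)cc1C(N)=O` and compound 2 `COc1c(NS(=O)(=O)c2ccc(F)cc2)cc(-c2ccc3nc(NC(=O)C4CC4)sc3n2)cc1C(N)=O` share one core and differ by cyclopropylcarbonyl in place of cyclopropyl on a nitrogen on an aromatic ring. In a functional assay on MCF7 cells (Homo sapiens) for antiproliferative activity, read by MTT assay, with a stated time of 72 h (a higher number here means a weaker inhibitor, a lower number a stronger inhibitor), compound 1 gives 33100 nM, and compound 2 gives 22100 nM; the step of a 1.5-fold lower number from compound 1 to compound 2 (0.18 log units; within the scatter) stays within the scatter. Compound 3 `COc1c(NS(=O)(=O)c2ccc(F)cc2)cc(-c2ccc3nc(NC4CC4)sc3c2)cc1C(N)=O` carries another core, and the difference between the two cores is not broken down here. In this assay compound 3 is recorded as "not determined" (no result reported), so no number stands for it. Compound 4 `COc1c(NS(=O)(=O)c2ccc(F)cc2)cc(-c2ccc3nc(NC(=O)C4CC4)sc3c2)cc1C(N)=O` differs from compound 3 by cyclopropylcarbonyl in place of cyclopropyl on a nitrogen on an aromatic ring, the same change as from compound 1 to compound 2, at the same place. That change gave a step within the scatter, and a step of similar size is expected here; with no number for compound 3 and the core difference unresolved, the expectation for compound 4 rests on compound 1 at 33100 nM and compound 2 at 22100 nM. Compound 4 is estimated at 25000 nM, expected to fall between 8000 nM and 80000 nM.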

Compound 4, half-maximal inhibitory concentration: 1580 nM
Compound 4: middle estimate off by 16-fold (1.20 log units), on the high side; the measured number lies below the stated range.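

No step can be read from compound 3 to compound 4: in this assay compound 4 gives 1580 nM and compound 3 has no number. The compounds shown leave open how cyclopropylamino to (cyclopropylcarbonyl)amino acts on this core, and how the two cores compare. No evidence bears on this result.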